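This account rests on a few compounds, and the source may have more. Where it says the series, first, only, none or still open, it means among the compounds named here.

Measured so far:
compound 1 `COc1ccc(-c2cc(/C=C/C(=O)c3ccc(N)cc3)[nH]n2)cc1`, 98%
compound 2 `COc1ccc(-c2cc(/C=C/C(=O)c3ccc(N)cc3)[nH]n2)cc1OC`, 97%
compound 3 `COc1cc(C(=O)/C=C/c2cc(-c3cc(OC)c(OC)c(OC)c3)n[nH]2)cc(OC)c1OC`, 94%

In a functional assay on CCRF-CEM cells (Homo sapiens) for cytotoxicity, read by sulforhodamine B assay, with a stated time of 48 h, tested at 0.1 uM (a lower number here means a stronger effect, a higher number a weaker effect of the compound at the concentration tested), these three read-outs lie within the usual scatter of one another. Among the measured compounds shown here, the one counted step, a number 1 percentage points higher from compound 2 to compound 1 (within the scatter), comes from the change (hydrogen in place of methoxy on an aromatic carbon). Compound 4 `COc1ccc(-c2cc(/C=C/C(=O)c3cc(OC)c(OC)c(OC)c3)[nH]n2)cc1OC` has not been measured; it differs from compound 3 by hydrogen in place of methoxy on an aromatic carbon. This is the same kind of change as that from compound 2 to compound 1, not the same: here the place is also meta to a methoxy group. The difference between the cores of compound 3 and compound 2 is not broken down here. The step of a number 1 percentage points higher from compound 3 to compound 4 (within the scatter) is expected to stay within the scatter, because a number 1 percentage points higher from compound 2 to compound 1 (within the scatter) did. Compound 4 is estimated at 95%, between 88% and 100%.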

Compound 4, a percentage reported as activity, at one concentration (the size of the read-out at that concentration, not a potency): 91%
Compound 4: middle estimate off by 4 percentage points, on the high side, and the stated range covers the measured number.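

In this assay, hydrogen in place of methoxy on an aromatic carbon of the core of compound 3 gives a number 3 percentage points lower from compound 3 to compound 4 (within the scatter). Set beside the earlier step on the other core, the change carries over without a detectable difference: the same change on two cores in this assay, a number 1 percentage points higher (within the scatter) from compound 2 to compound 1 and a number 3 percentage points lower (within the scatter) from compound 3 to compound 4, 4 percentage points apart, within the scatter of two such steps This shows only that the change stays within the scatter on these two cores at the one concentration tested; it does not show that the two steps are equal, or that the change is without effect on other cores or at other concentrations.

Still open, as far as these compounds go, is whether a group other than hydrogen in the same place, such as ethoxy, a carboxylic acid or a fluorine atom, would give a step beyond the scatter.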